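Replacing 4-fluorophenyl with 2,4-dimethoxyphenyl on the shared core

A few compounds are considered here, and "the series" means these few. Any claim that something is new, unique, unknown or untested is made for them only; others in the source may bear on it.

In a functional assay on DU-145 cells (Homo sapiens) for inhibition, read by trypan blue exclusion, with a stated time of 96 h (a higher number here means a weaker inhibitor of growth, a lower number a stronger inhibitor of growth), compound 3 (`O=C(/C(=C\c1ccc(F)cc1)S(=O)(=O)c1ccc(Br)cc1)c1ccc(Br)cc1`) gives 4000 nM as the lowest of the two numbers in hand. Compound 1 (`O=C(/C(=C\c1ccc(F)c([N+](=O)[O-])c1)S(=O)(=O)c1ccc(Br)cc1)c1ccc(Br)cc1`) stands nearest to it with 25000 nM as its value. The third measured member, compound 2 (`COc1cc(OC)c(/C=C(\C(=O)c2ccc(Br)cc2)S(=O)(=O)c2ccc(Br)cc2)c(OC)c1`), gives > 100000 nM as its result, and this is a limit of the assay and not a number.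

Compound 4 (`COc1ccc(/C=C(\C(=O)c2ccc(Br)cc2)S(=O)(=O)c2ccc(Br)cc2)c(OC)c1`) keeps the shared core but carries 2,4-dimethoxyphenyl in place of 4-fluorophenyl on a double-bonded chain carbon bound to a double-bonded chain carbon. Among the compounds with values here, only one measured step is available: hydrogen in place of nitro on an aromatic carbon gives a 6.3-fold lower number from compound 1 to compound 3 (0.80 log units; beyond the scatter) in this series. It shows that a change on this aromatic group can shift the number, but it is a different change and sets only a rough scale. Compound 2 also bears methoxy groups at that place, which points towards a higher number in this assay and thus a weaker inhibitor of growth. A step of similar size to the nitro step, beyond the scatter, is therefore expected. The expected change is a 5.0-fold higher number from compound 3 to compound 4 (0.70 log units; beyond the scatter) on this limited evidence. For compound 4 the estimate is 20000 nM with an expected range from 6000 nM to 70000 nM in this assay once tested.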

Compound 4, concentration for 50% growth inhibition: 8000 nM
Compound 4: the middle estimate sits 2.5-fold (0.40 log units) above what was measured, and the stated range covers the measured number.
By their numbers in this assay, from the lowest: compounds 3 and 4 (each within the scatter of the next); then compound 1. At a limit, above all of these: compound 2.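

In this assay, the step of a 2.0-fold higher number from compound 3 to compound 4 (0.30 log units; within the scatter) places 2,4-dimethoxyphenyl and 4-fluorophenyl on a double-bonded chain carbon bound to a double-bonded chain carbon level with each other, which shows that methoxy groups at this place do not always go with the high number of compound 2. Hydrogen in place of methoxy on an aromatic carbon gives an at least 12-fold lower number from compound 2 to compound 4 (1.09 log units; beyond the scatter), separating two compounds that differ by that one methoxy group, while 2,4-dimethoxyphenyl in place of 4-fluoro-3-nitrophenyl gives a 3.1-fold lower number from compound 1 to compound 4 (0.49 log units; beyond the scatter). The number for compound 2 is a limit of the assay and not a number, so the full size of its step stays unknown: the limit of > 100000 nM in this assay, at which 1 of the 4 values shown sits.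

The compounds shown leave open how this aromatic group would read in this assay with a single methoxy group, a hydroxyl group or an amine in place of the groups seen here. They also leave open whether the step between compound 2 and compound 4 would keep its size if the bromine atoms on the shared core were exchanged for chlorine.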